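The source may hold more compounds than are shown below. What is called first, only, known or untested is meant among the compounds shown, and "the series" means these compounds.

Measured so far in a functional assay on SF-295 cells (Homo sapiens); on this read-out lower numbers stand for stronger inhibition of growth and higher numbers for weaker inhibition of growth: compound 1 `Oc1cc(-c2ccc(Cl)cc2)nc2ncccc12` gives 40700 nM; compound 2 `COc1cccc(-c2cc(O)c3c(C)cc(C)nc3n2)c1` gives 417 nM; compound 3 `Cc1ccnc2nc(-c3ccc(Cl)cc3)cc(O)c12` gives 5370 nM.

Compound 2 has the lowest number of the three. How its core differs from the core of compound 3 is not broken down here. Within the core of compound 3, one change is known: hydrogen in place of methyl on an aromatic carbon, and the step it made was a 7.6-fold higher number from compound 3 to compound 1 (0.88 log units; beyond the scatter).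

Compound 4 `COc1cccc(-c2cc(O)c3c(C)ccnc3n2)c1` is not yet measured. It is obtained from compound 2 by hydrogen in place of methyl on an aromatic carbon. This is the same kind of change, but the place differs: in compound 3 the methyl sits ortho to a fused ring and opposite the ring nitrogen, whereas in compound 2 it sits next to the ring nitrogen, meta to a methyl group and para to a fused ring. Because the only comparable case, a 7.6-fold higher number from compound 3 to compound 1 (0.88 log units; beyond the scatter), weakened growth inhibition, a loss is expected here too, somewhat smaller given the different place: a 3.6-fold higher number from compound 2 to compound 4 (0.56 log units; beyond the scatter). Compound 4 is therefore estimated at 1500 nM, most likely between 500 nM and 5000 nM.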

Compound 4, concentration for 50% growth inhibition: 28.8 nM
For compound 4 the middle estimate is 52-fold (1.72 log units) above the measured one; the whole stated range lies above it.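

In this assay putting hydrogen in place of the methyl group gave a 14-fold lower number from compound 2 to compound 4 (1.16 log units; beyond the scatter) and thus stronger inhibition of growth, a large step. The same change weakened inhibition on the other core, so its effect does not carry from one core to the other in this series: the same change on two cores in this assay, a 7.6-fold higher number (0.88 log units; beyond the scatter) from compound 3 to compound 1 and a 14-fold lower number (1.16 log units; beyond the scatter) from compound 2 to compound 4, 110-fold (2.04 log units) apart, beyond the scatter of two such steps

For the compounds shown here, with only two such steps, and with the methyl group leaving a different place on each core, this does not show whether the place or the rest of the molecule sets the direction.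

The compounds shown leave open how other groups, such as an amine or a longer chain, would behave where that methyl group stood. Also open, on these data alone, is what the remaining methyl group on the core of compound 4 contributes.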